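A few compounds are considered here, and "the series" means these few. Any claim that something is new, unique, unknown or untested is made for them only; others in the source may bear on it.

Of the compounds shown here, two sharing one core have been measured in a physicochemical assay for lipophilicity, using the shake flask method, measured as octanol-water partition, at pH 7.4; a lower number here means a more polar compound, a higher number a more lipophilic compound. Compound 1 (`CC(=O)N[C@@H]1CCC[C@H](C(=O)Nc2cc(-c3cnn4c3CC(C)(C)C4)ccn2)C1`), with hydrogen on the aromatic carbon in question, gives 2.8. Compound 2 (`CC(=O)N[C@@H]1CCC[C@H](C(=O)Nc2cc(-c3cnn4c3CC(C)(C)C4)c(Cl)cn2)C1`), with chloro on that carbon, gives 3.8, the higher of the two numbers. Among the measured compounds shown here, the only measured step is a number 1.00 log units higher from compound 1 to compound 2 (beyond the scatter), for chloro in place of hydrogen on an aromatic carbon.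

Compound 3 (`CC(=O)N[C@@H]1CCC[C@H](C(=O)Nc2cc(-c3cnn4c3CC(C)(C)C4)c(C)cn2)C1`) has not yet been measured in this assay. Its difference from compound 2 is methyl in place of chloro on an aromatic carbon. For the measured compounds named here, no measured step involves methyl, so the evidence is indirect. Going by the values given here, the one step that bears on the change is the move from compound 1 to compound 2, a number 1.00 log units higher from compound 1 to compound 2 (beyond the scatter), and it sets the span within which compound 3 is expected to fall. A result part of the way back towards compound 1 seems most likely. The expected move is a number 0.50 log units lower from compound 2 to compound 3 (beyond the scatter), a downward step. For compound 3 the estimated value is 3.3, with an expected range from 2.9 to 3.7.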

Compound 3, distribution coefficient: 3.1
The estimate for compound 3 lay 0.20 log units above the measured number; the range from low to high includes it.
By their numbers in this assay, from the lowest: compounds 1 and 3 (each within the scatter of the next); then compound 2.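

In this assay, the same aromatic carbon of a six-membered aromatic ring with 1 nitrogen separates two substituents of 1 heavy atom each: methyl in place of chloro gives a number 0.70 log units lower from compound 2 to compound 3 (beyond the scatter), so the number seen with chloro does not carry over to methyl. Methyl in place of hydrogen gives a number 0.30 log units higher from compound 1 to compound 3 (within the scatter), which means that hydrogen and methyl cannot be told apart at this position in this assay, while chloro stands clear of both. Nothing shown here explains why chloro and methyl part in this way.

From the compounds shown here alone, what stays open is how other groups on this carbon would behave, for instance whether fluoro, methoxy or a nitrile would fall with chloro or with hydrogen and methyl. The compounds shown also leave open whether the gap between chloro and methyl would persist if the acetyl amino group on the saturated part of the shared core gave way to an amine or a carboxylic acid.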